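Growth inhibition notes: a chloro step from compound 3

A few compounds are considered here, and "the series" means these few. Any claim that something is new, unique, unknown or untested is made for them only; others in the source may bear on it.

Of the compounds shown here, three have been measured so far in a functional assay on MDA-MB-231 cells (Homo sapiens) for inhibition, read by sulforhodamine B assay, with a stated time of 48 h; a lower number here means a stronger inhibitor of growth, a higher number a weaker inhibitor of growth. Compound 1 (`CN(C)/C=C/C(=O)c1nn(-c2ccccc2)c(-c2ccccc2)c1C#N`) gives 50400 nM there, compound 2 (`N#Cc1c(-c2nnc(O)c3nn(-c4ccccc4)cc23)nn(-c2ccccc2)c1-c1ccccc1`) gives 6210 nM and compound 3 (`N#Cc1c(-c2nnc(-c3nn(-c4ccccc4)c(-c4ccccc4)c3C#N)c3nn(-c4ccccc4)cc23)nn(-c2ccccc2)c1-c1ccccc1`) gives 52400 nM in the same read-out. Compound 3 carries the highest of the three numbers, yet it lies within the scatter of compound 1. Compound 2 has the lower number, and its gap to compound 3 is beyond the scatter.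

Compound 4 (`N#Cc1c(-c2nnc(-c3nn(-c4ccccc4)c(-c4ccccc4)c3C#N)c3nn(-c4ccc(Cl)cc4)cc23)nn(-c2ccccc2)c1-c1ccccc1`) departs from compound 3 in one place: chloro in place of hydrogen on an aromatic carbon (chloro in place of hydrogen on an aromatic carbon, para to a large group), so a phenyl becomes a 4-chlorophenyl. Within the data shown here, no measured pair shows this change, so the expectation starts from the value of compound 3 alone. In this assay the expected step, a 1.5-fold lower number from compound 3 to compound 4 (0.18 log units; within the scatter), stays within the scatter, with a slight lean toward a lower number. Compound 4 is estimated at 35000 nM, with an expected range from 12000 nM to 85000 nM.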

Compound 4, concentration for 50% growth inhibition: 7900 nM
For compound 4 the middle estimate is 4.4-fold (0.65 log units) above the measured one; measured number outside the range, below it.
By their numbers in this assay, from the lowest: compounds 2 and 4 (each within the scatter of the next); then compounds 1 and 3 (each within the scatter of the next).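

In this assay the series now has its first step at a single place: a 6.6-fold lower number from compound 3 to compound 4 (0.82 log units; beyond the scatter), with chloro in place of hydrogen on an aromatic carbon, para to a large group. This shows that the number responds to a change of one heavy atom at this position, even in a compound as large as compound 3, although the step remains a single reading in one assay. Nothing measured here accounts for the size of this step.

As far as these compounds go, whether the step is specific to chloro or would also follow from another group at this position remains open, and fluoro, methoxy or an amine there would test this. Also open, from the compounds shown here alone, is whether the phenyl to 4-chlorophenyl change gives a similar step on the other phenyl rings of the compound.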